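Swapping a para group on a pyrazine hydrazone

The compounds below may be only part of what the source reports. "The series", "measured", "known", "first", "only" and "open" are said of these compounds alone.

Measured so far:
compound 1 `O=C(N/N=C/c1ccc(O)cc1)c1cnccn1` gives 43.1%
compound 2 `CC(C)c1ccc(/C=N/NC(=O)c2cnccn2)cc1` gives 19.4%

In a functional assay on the whole organism (strain Swiss) for inhibition, with Mus musculus as the target, with stated times of 40 min and 6 h, at a dose of 100 mg/kg by the oral route (a lower number here means less inhibition, a higher number more inhibition at the dose given (going by the name of the read-out)), compound 2 stands lowest of the two numbers; its nearest neighbour is compound 1, with a number 23.7 percentage points lower from compound 1 to compound 2 (beyond the scatter). Compound 3 `O=C(N/N=C/c1ccc(C(F)(F)F)cc1)c1cnccn1` differs from compound 2 by trifluoromethyl in place of isopropyl on an aromatic carbon. Among the compounds with values here, no measured step covers this exchange; the only step at this place shows that changing the group there moves the read-out modestly. A step of no clear direction is therefore expected, likely within the scatter, a number 5.6 percentage points higher from compound 2 to compound 3 (within the scatter). Compound 3 is estimated at 25%, with a range from 5% to 50%.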

Compound 3, a percentage reported as inhibition, in the whole organism at one dose (the size of the read-out at that dose, not a potency): 0%
The estimate for compound 3 lay 25 percentage points above the measured number, and the stated range ends above it.
By their numbers in this assay, from the lowest: compound 3; then compound 2; then compound 1.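

Trifluoromethyl on this aromatic carbon gives a number 19.4 percentage points lower from compound 2 to compound 3 (beyond the scatter) in this assay. Against hydroxy, the same group gives a number 43.1 percentage points lower from compound 1 to compound 3 (beyond the scatter). The read-out at this position therefore separates not only hydroxy from isopropyl but also isopropyl from trifluoromethyl, two groups with no hydrogen-bond donors or acceptors. Nothing available here explains this difference. Going by these compounds, whether an amine or a carboxylic acid at this carbon would give a read-out nearer that of compound 1 remains open.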